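The source may hold more compounds than are shown below. What is called first, only, known or untested is meant among the compounds shown, and "the series" means these compounds.

Compound 1, `CC(=O)N1CCC(C[C@@H](c2nc3cc(F)ccc3n2C)N2C(=O)CN(c3ccc(Oc4ccccc4)cc3)C2=O)CC1`, in a functional assay on Hep 3B2 cells (Homo sapiens) for cytotoxicity, read by MTT assay (on this read-out higher numbers stand for weaker inhibition and lower numbers for stronger inhibition), gives > 100000 nM, which is a limit of the assay and not a number.
Compound 2, `CC(=O)N1CCC(C[C@@H](c2nc3ccc(Cl)cc3n2C)N2C(=O)CN(c3ccc(Oc4ccccc4)cc3)C2=O)CC1`, in this assay gives > 100000 nM, again a limit of the assay rather than a number.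
Compound 3, `CC(C)C(=O)N1CCC(C[C@@H](c2nc3cc(F)ccc3n2C)N2C(=O)CN(c3ccc(Oc4ccccc4)cc3)C2=O)CC1`, in this assay gives > 100000 nM, also a limit of the assay and not a number.

Compound 1 and compound 2 differ in one place: 6-chloro-1-methyl-1H-benzimidazol-2-yl in place of 5-fluoro-1-methyl-1H-benzimidazol-2-yl on a saturated chain carbon bound to an amide-type nitrogen in a ring and a saturated chain carbon. The step this makes is a step that the two limits leave unreadable from compound 1 to compound 2, so its size cannot be read from two limits. Compound 3 differs from compound 1 by isopropyl in place of methyl on a carbonyl carbon. Compound 4, `CC(C)C(=O)N1CCC(C[C@@H](c2nc3ccc(Cl)cc3n2C)N2C(=O)CN(c3ccc(Oc4ccccc4)cc3)C2=O)CC1`, still to be measured in this assay, differs from compound 3 by 6-chloro-1-methyl-1H-benzimidazol-2-yl in place of 5-fluoro-1-methyl-1H-benzimidazol-2-yl on a saturated chain carbon bound to an amide-type nitrogen in a ring and a saturated chain carbon, the same change as that from compound 1 to compound 2, at the same place. The expected step from compound 3 to compound 4 is a number no higher from compound 3 to compound 4 (the limit leaves the size open), because of the limit of > 100000 nM in this assay, at which 3 of the 3 values shown sit, so there is no sign that any of these changes moves the read-out. Compound 4 is therefore estimated at 100000 nM in this assay, most likely reported again as a limit.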

Compound 4, half-maximal inhibitory concentration: > 100000 nM
Compound 4: no number, only a limit (the forecaster's own chance of this, stated with the estimate: 90%); the middle value lies on the limit itself.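

Neither the step from compound 3 to compound 4 nor the step from compound 2 to compound 4 can be read: each joins two limits of the assay, not two numbers. The four compounds shown leave open whether 6-chloro-1-methyl-1H-benzimidazol-2-yl in place of 5-fluoro-1-methyl-1H-benzimidazol-2-yl, or isopropyl in place of methyl, changes the read-out in this assay at all.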